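The source may report more compounds than this note shows. Statements on the series, on what has been measured and on what is new or still open speak of the compounds shown alone.

Compounds measured so far in a physicochemical assay for solubility, read by HPLC, measured as kinetic solubility, at pH 4; on this read-out lower numbers stand for lower solubility and higher numbers for higher solubility

Compound 1 (`FC(F)(F)c1c(CN2CCCC(c3ccccc3)C2)ccn2c(CC3CC3)nnc12`) gives 91000 nM
Compound 2 (`Fc1ccccc1C1CCN(Cc2ccn3c(CC4CC4)nnc3c2C(F)(F)F)CC1`) gives > 100000 nM

The reading of compound 2 at > 100000 nM is only a limit of the assay and not a number. Compound 2 therefore has no exact place on the scale, whereas compound 1 has a measured value. Compound 3 (`Fc1ccc(COC2CCN(Cc3ccn4c(CC5CC5)nnc4c3C(F)(F)F)CC2)c(F)c1`), still unmeasured, carries (2,4-difluorobenzyl)oxy in place of 2-fluorophenyl on a saturated ring carbon. For the measured compounds named here, no measured step bears on this change. A moderate fall in this assay beyond the usual scatter is expected, though compound 3 could also reach the limit. The estimated step is an at least 2.5-fold lower number from compound 2 to compound 3 (0.39 log units; beyond the scatter) on this reckoning. Compound 3 is expected at 40000 nM with an estimated range from 12000 nM to 100000 nM as the likely span of results.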

Compound 3, solubility: > 100000 nM
Compound 3: only a limit was reported; the forecaster's own chance of this, stated with the estimate: 25%; middle value at least 2.5-fold (0.39 log units) away from the limit.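

In this assay compound 3 gives > 100000 nM, which is a limit of the assay and not a number. Compound 2 also stands at a limit, so no step from compound 2 to compound 3 can be read: the limit of > 100000 nM in this assay, at which 2 of the 3 values shown sit.

The compounds shown leave open whether (2,4-difluorobenzyl)oxy in place of 2-fluorophenyl changes the read-out at all, and by how much.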